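Vinyl for Bromo on the Shared Core of Compound 2

The source may hold more compounds than are shown below. What is called first, only, known or untested is meant among the compounds shown, and "the series" means these compounds.

Measured so far:
Compound 1, `CCCCCCCCC(=O)NCc1cc(OC)c(O)cc1Cl`, gives 50.3 nM in an assay on HEK293 cells for inhibition of transient receptor potential cation channel subfamily V member 1 (Homo sapiens); on this read-out higher numbers stand for weaker inhibition and lower numbers for stronger inhibition.
Compound 2, `CCCCCCCCC(=O)NCc1cc(Br)c(O)c(OC)c1`, gives 252 nM in this assay.

Compound 2 stands highest of the two numbers, meaning the weaker inhibition; its nearest neighbour, compound 1, shows a lower number, and the gap between the two lies beyond the usual scatter. The two compounds differ in several places at once, so no single step can be read from them.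

Compound 3, `C=Cc1cc(CNC(=O)CCCCCCCC)cc(OC)c1O`, has not been measured. It differs from compound 2 in one place: vinyl in place of bromo on an aromatic carbon. Both groups are small, uncharged and carry no hydrogen-bond donors or acceptors, and nothing measured here speaks to what this swap does. A step of no more than the scatter is expected, in either direction, so the estimate for compound 3 is 200 nM (range 60 nM to 700 nM), a step of a 1.3-fold lower number from compound 2 to compound 3 (0.10 log units; within the scatter).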

Compound 3, half-maximal inhibitory concentration: 390 nM
Compound 3: the middle estimate sits 2.0-fold (0.29 log units) below what was measured, within the range that was stated.
By their numbers in this assay, from the lowest: compound 1; then compounds 2 and 3 (each within the scatter of the next).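

In this assay, vinyl in place of bromo on this aromatic carbon, ortho to a hydroxy group, gives a 1.5-fold higher number from compound 2 to compound 3 (0.19 log units; within the scatter), so compound 2 and compound 3 cannot be told apart. On this shared core, then, bromine itself is not needed at this position: a group made only of carbon and hydrogen serves here with no readable difference. Nothing measured here offers an explanation for this result.

On these data alone, whether an amine or a carboxylic acid at this position would shift the number beyond the scatter remains open. Compound 1 differs from compound 2 in several places at once, so the compounds shown cannot say which of those places accounts for the gap between them.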